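The source may hold more compounds than are shown below. What is called first, only, known or untested is meant among the compounds shown, and "the series" means these compounds.

Working notes on the series. Compound 1 `C=CC(=O)Nc1cccc(Oc2nc(Nc3ccn(C)n3)nc3c2CSCC3)c1` carries a vinyl group on the carbonyl carbon, and in a functional assay on HeLa cells (Homo sapiens) for antiproliferative activity, read by MTT assay, with a stated time of 72 h (a lower number here means a stronger inhibitor, a higher number a weaker inhibitor), compound 1 gives 25800 nM. Compound 2 `CC/C=C/C(=O)Nc1cccc(Oc2nc(Nc3ccn(C)n3)nc3c2CSCC3)c1` has but-1-en-1-yl there; in this assay compound 2 reaches only a limit of the assay, > 50000 nM. Compound 3 `CCC/C=C/C(=O)Nc1cccc(Oc2nc(Nc3ccn(C)n3)nc3c2CSCC3)c1` carries pent-1-en-1-yl, and in this assay compound 3 gives 17000 nM, with compound 1 the nearest neighbour: a 1.5-fold lower number from compound 1 to compound 3 (0.18 log units; within the scatter). The remaining steps are an at least 1.9-fold higher number from compound 1 to compound 2 (0.28 log units; that floor lies within the scatter) and an at least 2.9-fold lower number from compound 2 to compound 3 (0.46 log units; beyond the scatter), the latter resting on (the limit of > 50000 nM in this assay, at which 1 of the 3 values shown sits).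

Compound 4 `CC(C)=CC(=O)Nc1cccc(Oc2nc(Nc3ccn(C)n3)nc3c2CSCC3)c1` differs from compound 3 by 2-methylprop-1-en-1-yl in place of pent-1-en-1-yl on a carbonyl carbon. Going by the values given here, all three measured steps vary this same chain on the carbonyl carbon, and only the one that leans on a limit exceeds the scatter. For compound 4 no step beyond the scatter is therefore expected in this assay. The estimate for compound 4 is 25000 nM, within 10000 nM to 60000 nM. That estimate means an expected step of a 1.5-fold higher number from compound 3 to compound 4 (0.17 log units; within the scatter).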

Compound 4, half-maximal inhibitory concentration: > 50000 nM
Compound 4: only a limit was reported (the forecaster's own chance of this, stated with the estimate: 25%); at least 2.0-fold (0.30 log units) between middle value and limit.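

Compound 4 in this assay gives only a limit of the assay, > 50000 nM. Placing 2-methylprop-1-en-1-yl in place of pent-1-en-1-yl on the carbonyl carbon gives an at least 2.9-fold higher number from compound 3 to compound 4 (0.46 log units; beyond the scatter), so pent-1-en-1-yl now stands apart from two other chains at this position, while an at least 1.9-fold higher number from compound 1 to compound 4 (0.28 log units; that floor lies within the scatter) sets no order against the vinyl chain. Both steps rest on a limit, and the series now divides into two measured numbers and two limits: the limit of > 50000 nM in this assay, at which 2 of the 4 values shown sit.

The step between compound 2 and compound 4 cannot be read, so these two chains cannot be ranked against each other. Also open, from the compounds shown here alone, is whether a longer chain such as hex-1-en-1-yl, or a dimethylamino group at the end of the but-1-en-1-yl chain, would give a measured number rather than a limit.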